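Swapping a Sulfonamide for a Methyl Sulfone

The source may report more compounds than this note shows. Statements on the series, on what has been measured and on what is new or still open speak of the compounds shown alone.

Measured compounds:
Compound 1 `CS(=O)(=O)c1ccc(F)c(C#Cc2cc(Cl)ccc2OCC(=O)O)c1` gives 0.013 in an ADME assay on a cell-free system (plasma, Homo sapiens); a higher number here means a larger unbound share of the compound, a lower number a smaller unbound share.
Compound 2 `Cc1ccc(S(=O)(=O)NC(C)C)cc1C#Cc1cc(Cl)ccc1OCC(=O)O` gives 0.004 in this assay.

Compound 3 `COCCNS(=O)(=O)c1ccc(C)c(C#Cc2cc(Cl)ccc2OCC(=O)O)c1` gives "not determined" (no result reported) in this assay, so nothing can be said about where it stands on the numbers. The change to compound 4 `Cc1ccc(S(C)(=O)=O)cc1C#Cc1cc(Cl)ccc1OCC(=O)O` is methyl in place of (2-methoxyethyl)amino on a sulfonyl sulfur. Among the measured compounds shown here, with no value for compound 3, no step can be measured. Compound 1 carries the same methyl on its sulfonyl sulfur and gives 0.013, while compound 2 carries an amino group there and gives 0.004. Resting on these two, compound 4 is expected to sit near compound 1, at an estimated 0.01, within a range of 0.003 to 0.03.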

Compound 4, unbound fraction: 0.017
The estimate for compound 4 lay 1.7-fold (0.23 log units) below the measured number; measured number inside the range.
By their numbers in this assay, from the lowest: compound 2; then compounds 1 and 4 (each within the scatter of the next).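

In this assay, among the compounds shown here, methyl in place of isopropylamino on a sulfonyl sulfur gives a 4.3-fold higher number from compound 2 to compound 4 (0.63 log units; beyond the scatter), the first measured step at this sulfur. Methyl in place of fluoro on an aromatic carbon gives a 1.3-fold higher number from compound 1 to compound 4 (0.12 log units; within the scatter), so this swap does not separate the two compounds in this assay. No measurement shown here accounts for either result. The step from compound 3 to compound 4 cannot be read. On these data alone, whether an ethyl or a plain amino group on the sulfonyl sulfur would give a number nearer compound 2 or compound 4 remains open.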